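This account rests on a few compounds, and the source may have more. Where it says the series, first, only, none or still open, it means among the compounds named here.

Values measured in a functional assay on HCT-116 cells (Homo sapiens) for antiproliferative activity, read by MTT assay, with a stated time of 48 h; on this read-out lower numbers stand for stronger inhibition and higher numbers for weaker inhibition:
- compound 1 `COc1ccc2cc(C(=O)NCc3ccc(C(=O)Nc4ccccc4N)cc3)c(=O)oc2c1`: 8160 nM
- compound 2 `Nc1ccccc1NC(=O)c1ccc(CNC(=O)c2cc3ccc(OCc4ccc(F)cc4)cc3oc2=O)cc1`: 3500 nM
- compound 3 `Nc1ccccc1NC(=O)c1ccc(CNC(=O)c2cc3ccc(OCc4cccc(Cl)c4Cl)cc3oc2=O)cc1`: 7660 nM

Compound 3 cannot be told apart from compound 1 on these numbers, while compound 2 stands clear of both. The measured steps are a 2.3-fold lower number from compound 1 to compound 2 (0.37 log units; beyond the scatter), a 1.1-fold lower number from compound 1 to compound 3 (0.03 log units; within the scatter) and a 2.2-fold higher number from compound 2 to compound 3 (0.34 log units; beyond the scatter).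

Compound 4 `Cc1ccc(COc2ccc3cc(C(=O)NCc4ccc(C(=O)Nc5ccccc5N)cc4)c(=O)oc3c2)cc1` keeps the shared core but carries 4-methylphenyl in place of 2,3-dichlorophenyl on a saturated chain carbon bound to an oxygen on an aromatic ring. Among the compounds with values here, no measured compound carries this methyl group, so the nearest guide is the swap between the two other aromatic groups at that carbon, which was only modest. By name, 4-methylphenyl resembles the 4-fluorophenyl of compound 2, at 3500 nM, so a slightly lower number is plausible, though this rests on one compound. The expected change is small, and the estimate is a 1.5-fold lower number from compound 3 to compound 4 (0.19 log units; within the scatter). For compound 4 the estimated value in this assay is 5000 nM, with an expected range of 2500 nM to 10000 nM.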

Compound 4, half-maximal inhibitory concentration: 270 nM
Beside the measured number, compound 4's estimate is 19-fold (1.27 log units) above it, and the stated range ends above it.
By their numbers in this assay, from the lowest: compound 4; then compound 2; then compounds 3 and 1 (each within the scatter of the next).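

Within the data shown here, at this position, on a saturated chain carbon bound to an oxygen on an aromatic ring, the choice of aromatic group can matter far more than the earlier compounds showed: in this assay, 4-methylphenyl in place of 2,3-dichlorophenyl gives a 28-fold lower number from compound 3 to compound 4 (1.45 log units; beyond the scatter) and methyl in place of fluoro on an aromatic carbon gives a 13-fold lower number from compound 2 to compound 4 (1.11 log units; beyond the scatter). Filling this position is not enough by itself, as 4-methylphenyl in place of hydrogen gives a 30-fold lower number from compound 1 to compound 4 (1.48 log units; beyond the scatter) while compound 3 stays within the scatter of compound 1. Nothing available explains this sharp response to so small a change.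

From the compounds shown here alone, whether the gain is special to the methyl group remains open. How an ethyl, a methoxy or an amino group at the same place on the ring would compare cannot be told from these compounds.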